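Aryl amine in place of the aminoethyl amide

This account rests on a few compounds, and the source may have more. Where it says the series, first, only, none or still open, it means among the compounds named here.

For the measured compounds named here, compound 2 `NCCC(=O)Nc1nc2ccc(NC(=O)c3c(Cl)cccc3Cl)cc2s1` stands at the highest of the two numbers known in a functional assay on WI-38 VA13 cells (Homo sapiens) for cytotoxicity; a lower number here means that less compound is needed, a higher number that more compound is needed for the effect: compound 2 gives 5.3 ug/mL, while compound 1 `O=C(Nc1ccc2nc(NC(=O)C3CCCCC3)sc2c1)c1c(F)cccc1C(F)(F)F` gives 0.032 ug/mL, a gap beyond the scatter. Compound 3 `COc1ccc(Nc2nc3ccc(NC(=O)c4c(Cl)cccc4Cl)cc3s2)cc1` differs from compound 2 in one place: 4-methoxyphenyl in place of (2-aminoethyl)carbonyl on a nitrogen on an aromatic ring. Going by the values given here, no measured step of this kind is available, so the size of the change is open. Because compound 1 reaches 0.032 ug/mL with a neutral amide in that position, a lower number is expected for compound 3, by a step of about a 6.6-fold lower number from compound 2 to compound 3 (0.82 log units; beyond the scatter). Compound 3 is therefore estimated at 0.8 ug/mL, within 0.15 ug/mL to 4 ug/mL.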

Compound 3, half-maximal effective concentration: 0.87 ug/mL
For compound 3 the middle estimate is 1.1-fold (0.04 log units) below the measured one; low and high end bracket the measured number.
By their numbers in this assay, from the lowest: compound 1; then compound 3; then compound 2.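

At the nitrogen on the aromatic ring, 4-methoxyphenyl in place of (2-aminoethyl)carbonyl gives a 6.1-fold lower number from compound 2 to compound 3 (0.78 log units; beyond the scatter) in this assay, so the group on this nitrogen alone can move the number beyond the scatter. The swap removes the carbonyl and the amine and adds an aromatic ring in a single step, so the step cannot be divided among these parts. No available data bear on the reason for the step.

Still open, from the compounds shown here alone, is whether the terminal amine, the carbonyl or the aromatic ring accounts for the step. An unsubstituted phenyl, a 4-hydroxyphenyl or an acetyl on the same nitrogen would help separate these contributions.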